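A few compounds are considered here, and "the series" means these few. Any claim that something is new, unique, unknown or untested is made for them only; others in the source may bear on it.

Measured in a functional assay on HT-29 cells (Homo sapiens) for antiproliferative activity, read by sulforhodamine B assay, with a stated time of 48 h; a lower number here means a stronger inhibitor, a higher number a weaker inhibitor:
- compound 1 `Cc1ccc(OS(=O)(=O)c2ccc(N3CCN(C)C3=O)cc2)cc1`: > 100000 nM (a limit of the assay, not a number)
- compound 2 `CCCN1CCN(c2ccc(S(=O)(=O)Oc3c(Cl)cc(Cl)cc3Cl)cc2)C1=O`: 56000 nM

In this assay, among the measured compounds shown here, compound 2 gives 56000 nM, the only actual number available, so there is no measured step to compare it with. Compound 3 `CCCN1CCN(c2ccc(S(=O)(=O)Oc3ccc(C)cc3)cc2)C1=O` has not yet been measured. It carries 4-methylphenyl in place of the 2,4,6-trichlorophenyl of compound 2, on an oxygen whose other neighbour is the sulfonyl sulfur: 4-methylphenyl in place of 2,4,6-trichlorophenyl on an oxygen.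

For the measured compounds named here, with no measured step to guide it, the expectation in this assay is only a small weakening, perhaps not beyond the scatter. Compound 1 also carries 4-methylphenyl and gives > 100000 nM, again only a limit. The expected change is a 1.4-fold higher number from compound 2 to compound 3 (0.15 log units; within the scatter). For compound 3 the estimated value is 80000 nM, with an expected range of 25000 nM to 200000 nM.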

Compound 3, half-maximal inhibitory concentration: 25000 nM
Compound 3: the middle estimate sits 3.2-fold (0.51 log units) above what was measured; the measured number falls inside the stated range.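

In this assay, among the compounds shown here, the step of a 2.2-fold lower number from compound 2 to compound 3 (0.35 log units; beyond the scatter) gives the first measured reading at this place, on an oxygen whose other neighbour is the sulfonyl sulfur: 4-methylphenyl in place of 2,4,6-trichlorophenyl goes with a modest gain, not a loss. A second change can now be read as well, ethyl in place of hydrogen on a saturated chain carbon bound to an amide-type nitrogen in a ring, with an at least 4.0-fold lower number from compound 1 to compound 3 (0.60 log units; beyond the scatter). The full size of that step stays open because compound 1 stands at a limit of the assay and not a number: the limit of > 100000 nM in this assay, at which 1 of the 3 values shown sits.

From the compounds shown here alone, what a plain phenyl or a 4-methoxyphenyl would give on that oxygen remains open, so the first step cannot be split between the chlorines leaving and the methyl entering. Going by these compounds, the effect of a longer chain on the amide-type nitrogen is also open.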